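Adding a Methoxy Group to Compound 2

The source may report more compounds than this note shows. Statements on the series, on what has been measured and on what is new or still open speak of the compounds shown alone.

Compound 1 `COc1cc(/C=N/NC(=O)c2ccncc2)cc(OC)c1OC`: 94%
Compound 2 `Oc1ccc(/C=N/Nc2nc3ccccc3s2)cc1O`: 7%

In a physicochemical assay on cells (Homo sapiens), with a stated time of 18 h, tested at 10 uM (on this read-out higher numbers stand for a weaker effect at the one concentration tested and lower numbers for a stronger effect), compound 2 gives 7%, the lowest of the two numbers, while compound 1 gives 94%, a number higher by a gap beyond the scatter. Compound 3 `COc1cc(/C=N/Nc2nc3ccccc3s2)cc(O)c1O` differs from compound 2 by methoxy in place of hydrogen on an aromatic carbon. Among the compounds with values here, no measured pair shows this change, so the step is expected to be small, toward a somewhat higher number or none beyond the scatter. For compound 3 the expected value in this assay is 15%, with a range from 4% to 40%. The expected step of a number 8 percentage points higher from compound 2 to compound 3 (within the scatter) is modest.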

Compound 3, a percentage reported as activity, at one concentration (the size of the read-out at that concentration, not a potency): 7%
Estimate against measurement, compound 3: 8 percentage points above, within the range that was stated.
By their numbers in this assay, from the lowest: compounds 2 and 3 (each within the scatter of the next); then compound 1.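

In this assay, methoxy in place of hydrogen on an aromatic carbon, ortho to a hydroxy group, gives no change at the digits printed from compound 2 to compound 3 (within the scatter). Within the data shown here, this is the first single-place change, and it shows that this position accepts a methoxy group without a shift beyond the scatter. Nothing measured here offers an explanation for this result. As far as these compounds go, whether an amine, a carboxylic acid or a longer chain such as butoxy at this position would give the same reading remains open. So does the outcome of replacing either hydroxy group with methoxy.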